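Cyclohexyl for benzyl on a permeability series

This account rests on a few compounds, and the source may have more. Where it says the series, first, only, none or still open, it means among the compounds named here.

Measured compounds:
Compound 1 `c1ccc(CCc2ccc3c(NCCCNCc4ccco4)ccnc3c2)cc1`: 23 10^-6 cm/s
Compound 2 `c1coc(CNCCCNc2ccnc3cc(CC4CCCCC4)ccc23)c1`: 23 10^-6 cm/s
Compound 3 `COc1cccc(CNCCCNc2ccnc3cc(CCc4ccccc4)ccc23)c1O`: 23 10^-6 cm/s

In an ADME assay for permeability, using PAMPA, with a stated time of 30 min, at pH 7.4 (a lower number here means that the compound crosses the layer more slowly, a higher number that the compound crosses the layer faster), compound 1 gives 23 10^-6 cm/s. Compound 2 differs from it by cyclohexyl in place of benzyl on a saturated chain carbon bound to an aromatic carbon, and this assay shows no change at the digits printed from compound 1 to compound 2 (within the scatter). Compound 3 differs from compound 1 in its core by 2-hydroxy-3-methoxyphenyl in place of furan-2-yl on a saturated chain carbon bound to an amine nitrogen, with no change at the digits printed from compound 1 to compound 3 (within the scatter). Compound 4 `COc1cccc(CNCCCNc2ccnc3cc(CC4CCCCC4)ccc23)c1O` has not yet been measured; it differs from compound 3 by cyclohexyl in place of benzyl on a saturated chain carbon bound to an aromatic carbon, the same change as that from compound 1 to compound 2, made at a place described in the same words. Compound 4 is therefore expected to show no change at the digits printed from compound 3 to compound 4 (within the scatter), because the same change gave no change at the digits printed from compound 1 to compound 2 (within the scatter). Compound 4 is estimated at 23 10^-6 cm/s, within 12 10^-6 cm/s to 46 10^-6 cm/s.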

Compound 4, apparent permeability: 23 10^-6 cm/s
For compound 4 middle estimate and measured number coincide at the digits printed; measured number inside the range.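

In this assay, cyclohexyl in place of benzyl gives no change at the digits printed from compound 3 to compound 4 (within the scatter), which matches the same change on the core of compound 1: the same change on two cores in this assay, no change at the digits printed (within the scatter) from compound 1 to compound 2 and no change at the digits printed (within the scatter) from compound 3 to compound 4, 1.0-fold (0.00 log units) apart, within the scatter of two such steps. Likewise, 2-hydroxy-3-methoxyphenyl in place of furan-2-yl gives no change at the digits printed from compound 2 to compound 4 (within the scatter), which matches the earlier step: the same change on two cores in this assay, no change at the digits printed (within the scatter) from compound 1 to compound 3 and no change at the digits printed (within the scatter) from compound 2 to compound 4, 1.0-fold (0.00 log units) apart, within the scatter of two such steps. Across these four compounds, both changes carry from one core to the other, but this is only agreement between steps that show no change, and it does not show that either change would behave the same way on any other core.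

The compounds shown leave open what a longer chain in place of cyclohexyl would do. They also leave open how a carboxylic acid or an amine in place of furan-2-yl would read.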